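Thiophen-2-yl for 4-methoxyphenyl in the iodo compounds

A few compounds are considered here, and "the series" means these few. Any claim that something is new, unique, unknown or untested is made for them only; others in the source may bear on it.

In a functional assay on HeLa cells (Homo sapiens) for cytotoxicity, read by MTT assay, with stated times of 3 h and 24 h (a lower number here means a stronger inhibitor, a higher number a weaker inhibitor), compound 2 `COc1ccc(C2=[N+]3C(=Nc4c(-c5ccccc5)c5c(n4[B-]3(F)F)-c3ccc(OC)cc3CC5)C(c3ccccc3)=C2I)cc1` gives 81 nM, within the scatter of compound 3 `COc1ccc2c(c1)CCc1c(-c3ccccc3)c3n(c1-2)[B-](F)(F)[N+]1=C(c2ccc(C)cc2)C(I)=C(c2ccccc2)C1=N3` at 110 nM, while compound 1 `COc1ccc2c(c1)CCc1c(-c3ccccc3)c3n(c1-2)[B-](F)(F)[N+]1=C(c2ccc(C)s2)C(Br)=C(c2ccccc2)C1=N3` stands far higher at 22600 nM.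

Compound 4 `COc1ccc2c(c1)CCc1c(-c3ccccc3)c3n(c1-2)[B-](F)(F)[N+]1=C(c2cccs2)C(I)=C(c2ccccc2)C1=N3` carries thiophen-2-yl in place of 4-methoxyphenyl on a carbon with a double bond to nitrogen.

Among the compounds with values here, the only measured step at this place is a 1.4-fold higher number from compound 2 to compound 3 (0.13 log units; within the scatter), and it keeps the six-membered ring. Within the data shown here, compound 1 also has a thiophene ring, but it differs from compound 4 in more than one place, with bromo instead of iodo, so it gives no clean step and only widens the upper range.

A small rise is expected in this assay, near the edge of the scatter: a 1.9-fold higher number from compound 2 to compound 4 (0.27 log units; within the scatter). For compound 4 the estimated value is 150 nM, with an expected range of 50 nM to 900 nM.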

Compound 4, half-maximal inhibitory concentration: 460 nM
For compound 4 the middle estimate is 3.1-fold (0.49 log units) below the measured one; low and high end bracket the measured number.
By their numbers in this assay, from the lowest: compounds 2 and 3 (each within the scatter of the next); then compound 4; then compound 1.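

In this assay, the group on the carbon with a double bond to nitrogen matters more than the earlier pair suggested: a 1.4-fold higher number from compound 2 to compound 3 (0.13 log units; within the scatter) stays within the scatter, but thiophen-2-yl moves the number beyond it, with a 5.7-fold higher number from compound 2 to compound 4 (0.75 log units; beyond the scatter) and a 4.2-fold higher number from compound 3 to compound 4 (0.62 log units; beyond the scatter). The two aryl compounds therefore sit together, with the thiophene compound apart from them. No measurement on hand accounts for this rise.

Open, from the compounds shown here alone, is whether the rise follows the five-membered ring or the sulfur atom. Also open, going by these compounds, is how a pyridine ring or a phenyl ring bearing an amine would read at this place.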